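One Ring Stereocentre Redrawn in Compound 2

The compounds below may be only part of what the source reports. "The series", "measured", "known", "first", "only" and "open" are said of these compounds alone.

In an ADME assay on the whole organism for metabolic stability, with Homo sapiens as the target, with a stated time of 21 days (a lower number here means that the compound disappears faster, a higher number that the compound lasts longer), compound 1 (`CO[C@@H]1[C@H](OC(=O)N[C@@H](C(N)=O)C(C)(C)O)CC[C@]2(CO2)[C@H]1[C@@]1(C)O[C@@H]1C[C@@H]1OC1(C)C`) gives 1.8 h as its half-life, and compound 2 (`CO[C@@H]1[C@H](OC(=O)N[C@@H](C(N)=O)C(C)C)CC[C@]2(CO2)[C@H]1[C@@]1(C)O[C@@H]1C[C@H]1OC1(C)C`) gives 1.3 h as its half-life. These two values lie within the usual scatter of each other, so compound 2 stands level with compound 1 on the numbers available.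

Compound 3 (`CO[C@@H]1[C@H](OC(=O)N[C@@H](C(N)=O)C(C)C)CC[C@]2(CO2)[C@H]1[C@@]1(C)O[C@@H]1C[C@@H]1OC1(C)C`) has not yet been measured. Its structure differs from that of compound 2 as follows: the two compounds have the same atoms and bonds and differ only in configuration as drawn: 1 of 8 stereo elements differ; a stereocentre at a saturated ring carbon is drawn R in compound 2 and S in compound 3. The two compounds have the same atoms and bonds, and a stereocentre at a saturated ring carbon is drawn R in compound 2 and S in compound 3.

Among the measured compounds shown here, no measured pair shows the effect of a change of this kind on this assay, so no step beyond the scatter is expected. The estimate therefore starts from compound 2 at 1.3 h and allows for compound 1 at 1.8 h as the only other measured reference. The expected change is a 1.2-fold higher number from compound 2 to compound 3 (0.06 log units; within the scatter) and remains an estimate. For compound 3 the estimated half-life is 1.5 h with 0.8 h to 2.8 h as its expected range.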

Compound 3, half-life: 1 h
Compound 3: the middle estimate sits 1.5-fold (0.18 log units) above what was measured; the measured number falls inside the stated range.
By their numbers in this assay, from the lowest: compounds 3, 2 and 1 (each within the scatter of the next).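

Among the compounds shown here, compound 3 supplies the first measured pair for this stereocentre at a saturated ring carbon: in this assay, redrawing it from R to S gives a 1.3-fold lower number from compound 2 to compound 3 (0.11 log units; within the scatter), so in this one pair the configuration there shows no step beyond the scatter. That step can be read as belonging to this stereocentre alone on one ground: the fact that compounds 2 and 3 differ only in the configuration as drawn

For the compounds shown here, compound 3 also gives a first reading at a second place, the saturated chain carbon bound to three saturated chain carbons, where hydrogen in place of hydroxy gives a 1.8-fold lower number from compound 1 to compound 3 (0.26 log units; within the scatter), again no step that stands clear of the scatter in this assay.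

Going by these compounds, whether the redrawing from R to S at the saturated ring carbon would give a similar step with hydroxy on that chain carbon remains open, as a single pair cannot show whether the result holds when the neighbouring structure is different. On these data alone, it also remains open whether an amine or a carboxylic acid on that saturated chain carbon, in place of hydrogen or hydroxy, would give a step beyond the scatter.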